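The source may hold more compounds than are shown below. What is called first, only, known or untested is meant among the compounds shown, and "the series" means these compounds.

Measured so far:
compound 1 `COc1ccc(C(=O)N2CCN(Cc3nc4ccccc4n3Cc3cccc(C)c3)CC2)cc1`: 55.5%
compound 2 `Cc1ccccc1Cn1c(CN2CCN(C(=O)C3CC3)CC2)nc2ccccc21`: 29.1%

In an assay on isolated protein for inhibition of aldehyde dehydrogenase 1A1 (Homo sapiens), read by spectrophotometry, tested at 10 uM (a lower number here means less inhibition, a higher number more inhibition at the concentration tested (going by the name of the read-out)), compound 2 gives 29.1%, the lower of the two numbers shown. Within the data shown here, compound 1 gives 55.5% in this assay, a gap beyond the scatter, but the two structures differ in more than one place, so no single step is known. Compound 3 `COc1cccc(Cn2c(CN3CCN(C(=O)C4CC4)CC3)nc3ccccc32)c1` has not been measured. It differs from compound 2 in one place: 3-methoxyphenyl in place of 2-methylphenyl on a saturated chain carbon bound to an aromatic nitrogen. Among the measured compounds shown here, with no comparable step to lean on, only a small shift in this assay is expected, and the step of a number 5.9 percentage points higher from compound 2 to compound 3 (within the scatter) is estimated to lie within the scatter. Compound 3 is expected to give about 35%, in a range from 10% to 62%.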

Compound 3, a percentage reported as inhibition, at one concentration (the size of the read-out at that concentration, not a potency): 44.4%
For compound 3 the middle estimate is 9.4 percentage points below the measured one; the range from low to high includes it.
By their numbers in this assay, from the lowest: compound 2; then compound 3; then compound 1.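

Among these compounds, this is the first single-place change that can be read in this assay. Replacing 2-methylbenzyl with 3-methoxybenzyl brings a number 15.3 percentage points higher from compound 2 to compound 3 (beyond the scatter), so the group on this saturated chain carbon bound to an aromatic nitrogen affects the read-out. No available evidence gives a reason for this rise.

The change swaps methyl for methoxy and alters the printed ring number at the same time, so the compounds shown leave open which of the two matters. From the compounds shown here alone, how an amine or a carboxylic acid would read on this ring also remains open.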